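The source may hold more compounds than are shown below. What is called first, only, known or untested is meant among the compounds shown, and "the series" means these compounds.

Going by the values given here, compound 2, with the structure `CCOc1ccc(/N=C/C2=C3NC=C(C(=O)O)C(=O)N3C(C)CC2)cc1`, stands at the low end of the two numbers so far in a functional assay on the whole organism with Rattus norvegicus as the target; on this read-out higher numbers stand for an effect only at larger amounts of compound and lower numbers for an effect already at smaller amounts: in this assay compound 2 gives 8.96 umol/kg. Among the compounds with values here, the only other measured compound is compound 1, built as `CCOC(=O)C1=CNC2=C(/C=N/c3ccc(C(=O)O)cc3)CCC(C)N2C1=O`, and in this assay compound 1 gives 67.1 umol/kg, a higher number that lies beyond the scatter of repeated measurements, so the two values differ in earnest rather than by chance. Compound 3, drawn as `CC1CCC(/C=N/c2ccc(CC(=O)O)cc2)=C2NC=C(C(=O)O)C(=O)N21`, has not yet been measured in this assay. Its structure differs from compound 2 in one place: carboxymethyl in place of ethoxy on an aromatic carbon. Within the data shown here, no step between two measured compounds matches this change, so any expectation rests only on the two values at hand. Compound 1, which also carries an acid on its aromatic ring, gives the weaker number of the two, and on that thin basis the author expects the step of a 3.3-fold higher number from compound 2 to compound 3 (0.52 log units; beyond the scatter) to be an increase somewhat beyond the scatter. For compound 3 the expected value in this assay is therefore 30 umol/kg, with a plausible range from 9 umol/kg to 100 umol/kg.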

Compound 3, dose for 50% inhibition: 5.8 umol/kg
For compound 3 the middle estimate is 5.2-fold (0.71 log units) above the measured one; measured number outside the range, below it.
By their numbers in this assay, from the lowest: compounds 3 and 2 (each within the scatter of the next); then compound 1.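

In this assay, carboxymethyl in place of ethoxy on the aromatic carbon para to a large group gives a 1.5-fold lower number from compound 2 to compound 3 (0.19 log units; within the scatter), so this exchange does not separate the two compounds on this read-out. It shows that this position can carry a group with a hydrogen-bond donor and one more heavy atom in place of ethoxy without a change beyond the scatter, something the earlier pair, which differs in more than one place, could not show. No measurement of any property of these compounds bears on this result.

Open, from the compounds shown here alone, is how far this tolerance extends at the same place, for example to a longer chain ending in a carboxylic acid, to a methyl ester of the carboxymethyl group, or to an amine on a short chain. The compounds shown also leave open whether the result depends on the carboxylic acid of carboxymethyl at all, since a neutral group of the same length, such as a hydroxyethyl chain, does not appear among them.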